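The source may report more compounds than this note shows. Statements on the series, on what has been measured and on what is new or still open speak of the compounds shown alone.

Series notes. In a functional assay on MDA-MB-231 cells (Homo sapiens) for antiproliferative activity, read by MTT assay, with a stated time of 48 h (a lower number here means a stronger inhibitor, a higher number a weaker inhibitor), compound 1 `CCOC(=O)CN(Cc1ccccc1)c1nc(Nc2ccc(Cl)cc2)ncc1[N+](=O)[O-]` gives 34400 nM, compound 2 `COC(=O)CN(C)c1nc(NCc2ccccc2)ncc1[N+](=O)[O-]` gives 61100 nM and compound 3 `CCOC(=O)CN(Cc1ccccc1)c1nc(NCc2cccc(OC)c2)ncc1[N+](=O)[O-]` gives 80700 nM. For the measured compounds named here, compound 3 carries the highest of the three numbers: compound 2 sits within the scatter of it, whereas the single measured step, a 2.3-fold higher number from compound 1 to compound 3 (0.37 log units; beyond the scatter), lies beyond it. Compound 4 `CCOC(=O)CN(Cc1ccccc1)c1nc(NCc2ccccc2)ncc1[N+](=O)[O-]` differs from compound 3 by hydrogen in place of methoxy on an aromatic carbon. Going by the values given here, no measured step removes a methoxy group on its own; the one step recorded swaps 4-chlorophenyl for 3-methoxybenzyl and does not isolate this change. With nothing pointing either way, no step beyond the scatter is expected in this assay, and the expected step is a 1.2-fold lower number from compound 3 to compound 4 (0.09 log units; within the scatter). Compound 4 is therefore estimated at 65000 nM, within 30000 nM to 140000 nM.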

Compound 4, half-maximal inhibitory concentration: 82400 nM
Compound 4: the middle estimate sits 1.3-fold (0.10 log units) below what was measured, within the range that was stated.
By their numbers in this assay, from the lowest: compounds 1, 2, 3 and 4 (each within the scatter of the next, the first and the last beyond it).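

In this assay, for the compounds shown here, replacing methoxy with hydrogen at this aromatic carbon gives the first isolated reading of the change (a 1.0-fold higher number from compound 3 to compound 4 (0.01 log units; within the scatter)), and it shows no effect beyond the scatter. The step from 4-chlorophenyl to benzyl (a 2.4-fold higher number from compound 1 to compound 4 (0.38 log units; beyond the scatter)) is beyond the scatter and runs the same way as the step to 3-methoxybenzyl (a 2.3-fold higher number from compound 1 to compound 3 (0.37 log units; beyond the scatter)), so that rise does not depend on the methoxy group. No measurement offers an explanation for these results.

From the compounds shown here alone, whether an amine or a carboxylic acid at the same aromatic carbon would also leave the number unchanged remains open. The benzyl step also leaves the contribution of chlorine unseparated from that of the extra carbon link.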